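This account rests on a few compounds, and the source may have more. Where it says the series, first, only, none or still open, it means among the compounds named here.

Measured so far:
Compound 1 `Cn1c(=O)c2c(nc(SCc3ccccc3)n2C)n(C)c1=O`: in an assay on isolated protein for inhibition of Amine oxidase [flavin-containing] A (Homo sapiens), read by fluorescence (a higher number here means a weaker inhibitor, a lower number a stronger inhibitor), compound 1 gives 8220 nM.
Compound 2 `Cn1c(=O)c2c(nc(SCc3ccc(Br)cc3)n2C)n(C)c1=O`: in this assay compound 2 gives 2620 nM.

Of these two numbers, compound 1 has the higher one, so it is the weaker inhibitor of the pair. Within the data shown here, the only known step, a 3.1-fold lower number from compound 1 to compound 2 (0.50 log units; beyond the scatter), keeps the benzyl group and adds bromo to its ring. Compound 3 `CC(C)CCSc1nc2c(c(=O)n(C)c(=O)n2C)n1C` changes compound 1 elsewhere: isobutyl in place of phenyl on a saturated chain carbon bound to a sulfur. Among the measured compounds shown here, no measured step removes the ring itself, so this change has no direct precedent; the one step shows only that a substituent on that ring shifted the number modestly. Losing the ring altogether is a larger change, and the number for compound 3 is expected to move upward, toward a weaker inhibitor, with wide uncertainty, the expected step being a 1.7-fold higher number from compound 1 to compound 3 (0.23 log units; within the scatter). Compound 3 is therefore estimated at 14000 nM, within a range of 4000 nM to 50000 nM.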

Compound 3, half-maximal inhibitory concentration: 15200 nM
Estimate against measurement, compound 3: 1.1-fold (0.04 log units) below; measured number inside the range.
By their numbers in this assay, from the lowest: compound 2; then compounds 1 and 3 (each within the scatter of the next).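

In this assay, the aromatic ring turns out not to be required at this position: the change to isobutyl on a saturated chain carbon bound to a sulfur gives a 1.8-fold higher number from compound 1 to compound 3 (0.27 log units; within the scatter) and so leaves the open chain and the plain phenyl ring indistinguishable. Among these compounds, the larger gap is a 5.8-fold higher number from compound 2 to compound 3 (0.76 log units; beyond the scatter) and shows that, of these three compounds, only the one carrying the 4-bromophenyl group stands apart from the others. Nothing available here explains why these numbers fall as they do.

Going by these compounds, it remains open whether the chain itself matters, since a shorter ethyl group or a longer octyl chain could read differently. Also open, on these data alone, is whether an amine or a carboxylic acid at the end of the chain would be tolerated, and whether a bromo on another part of the ring would match compound 2.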